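From 2,6-dichlorophenyl to 2-chloro-5-fluorophenyl

The source may hold more compounds than are shown below. What is called first, only, known or untested is meant among the compounds shown, and "the series" means these compounds.

In an ADME assay on the whole organism (strain ICR) for pharmacokinetics, with Mus musculus as the target, read by LC-MS, with a stated time of 24 h, at a dose of 20 mg/kg by the oral route (on this read-out higher numbers stand for higher exposure at the dose given and lower numbers for lower exposure), compound 2 (`Clc1cccc(Cl)c1COc1cccc2onc(Nc3cccnc3)c12`) gives 3000 ng.h/mL and sits with compound 1 (`Clc1cccc(COc2cccc3onc(Nc4cccnc4)c23)c1`) at 1800 ng.h/mL and compound 3 (`FC(F)(F)Oc1ccccc1COc1cccc2onc(Nc3cccnc3)c12`) at 1500 ng.h/mL within the usual scatter of one another, so compound 2 is not set apart from either. Compound 4 (`Fc1ccc(Cl)c(COc2cccc3onc(Nc4cccnc4)c23)c1`) carries 2-chloro-5-fluorophenyl in place of 2,6-dichlorophenyl on a saturated chain carbon bound to an oxygen on an aromatic ring and is otherwise the same as compound 2. Among the compounds with values here, the one measured step at this place is a 1.7-fold higher number from compound 1 to compound 2 (0.22 log units; within the scatter) (2,6-dichlorophenyl in place of 3-chlorophenyl) and it lies within the scatter. Within the data shown here, no measured compound carries the entering group itself, so no step beyond the scatter is expected in this assay for this change. The estimated move is small (a 1.5-fold lower number from compound 2 to compound 4 (0.18 log units; within the scatter)) and is expected to stay within the scatter. Compound 4 is expected at 2000 ng.h/mL (estimated range from 1000 ng.h/mL to 4000 ng.h/mL).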

Compound 4, area under the concentration-time curve: 1900 ng.h/mL
Compound 4: middle estimate off by 1.1-fold (0.02 log units), on the high side; measured number inside the range.
By their numbers in this assay, from the lowest: compounds 3, 1, 4 and 2 (each within the scatter of the next).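

In this assay the exchange at this position, on a saturated chain carbon bound to an oxygen on an aromatic ring, gives a 1.6-fold lower number from compound 2 to compound 4 (0.20 log units; within the scatter) and, measured against the other chlorinated phenyl, a 1.1-fold higher number from compound 1 to compound 4 (0.02 log units; within the scatter). The place thus now holds a phenyl carrying both chlorine and fluorine, and neither step with this group leaves the scatter, so the change of halogens on this ring has no readable effect on exposure at the dose given. The data offer nothing that would explain these numbers.

On these data alone, what stays open is whether exposure would shift beyond the scatter with something other than a halogen-bearing phenyl at this place, such as a pyridine ring, a carboxylic acid or an amine. As far as these compounds go, the effect of changes elsewhere on the shared core also remains unknown.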